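Trifluoromethylphenyl ketone within the trimethoxyphenyl series

The source may report more compounds than this note shows. Statements on the series, on what has been measured and on what is new or still open speak of the compounds shown alone.

Compound 3 `COc1cc(-c2nnc3n2NC(c2ccco2)C(C(=O)c2cccs2)S3)cc(OC)c1OC` gives 78700 nM in a functional assay on A549 cells (Homo sapiens) for cytotoxicity, read by MTT assay, with a stated time of 48 h; a higher number here means a weaker inhibitor, a lower number a stronger inhibitor. Compound 1 `COc1cc(-c2nnc3n2NC(c2ccco2)C(C(=O)c2ccco2)S3)cc(OC)c1OC` gives 68700 nM, and the two stand within scatter of each other, as a 1.1-fold higher number from compound 1 to compound 3 (0.06 log units; within the scatter) shows. Compound 2 `COc1cc(-c2nnc3n2NC(c2ccco2)C(C(=O)C2CC2)S3)cc(OC)c1OC` returns only a limit, > 100000 nM, in this assay (the limit of > 100000 nM in this assay, at which 1 of the 3 values shown sits). The step from compound 2 to compound 3 is an at least 1.2-fold lower number from compound 2 to compound 3 (0.10 log units; that floor lies within the scatter), so the three ketones so far are spread narrowly. Compound 4 `COc1cc(-c2nnc3n2NC(c2ccco2)C(C(=O)c2ccc(C(F)(F)F)cc2)S3)cc(OC)c1OC` differs from compound 3 by 4-(trifluoromethyl)phenyl in place of thiophen-2-yl on a carbonyl carbon. Both earlier swaps at this carbonyl carbon stayed within the scatter, so no step beyond it is expected in this assay. Compound 4 is therefore expected at 70000 nM (range 30000 nM to 160000 nM), meaning an expected step of a 1.1-fold lower number from compound 3 to compound 4 (0.05 log units; within the scatter).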

Compound 4, half-maximal inhibitory concentration: 37200 nM
Compound 4: middle estimate off by 1.9-fold (0.27 log units), on the high side, within the range that was stated.
By their numbers in this assay, from the lowest: compounds 4, 1 and 3 (each within the scatter of the next, the first and the last beyond it). At a limit, above all of these: compound 2.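

4-(trifluoromethyl)phenyl on this carbonyl carbon gives the first step here between two exact numbers that lies beyond the scatter, a 2.1-fold lower number from compound 3 to compound 4 (0.33 log units; beyond the scatter) in this assay. The same group reads differently against the other two ketones: a 1.8-fold lower number from compound 1 to compound 4 (0.27 log units; within the scatter), while an at least 2.6-fold lower number from compound 2 to compound 4 (0.42 log units; beyond the scatter). Compound 2 counts only as a limit: the limit of > 100000 nM in this assay, at which 1 of the 4 values shown sits.

As far as these compounds go, whether this step belongs to the trifluoromethyl or to the phenyl ring itself stays open. Also open, from the compounds shown here alone, is whether a plain phenyl ketone, or a phenyl ketone carrying an amine or a carboxylic acid, would hold this level.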